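Moving a Trifluoromethyl Group onto a Second Core

A few compounds are considered here, and "the series" means these few. Any claim that something is new, unique, unknown or untested is made for them only; others in the source may bear on it.

Compound 1 `CC(O)(COc1ccc(C#N)cc1)C(=O)Nc1ccc(S(F)(F)(F)(F)F)cc1` was tested in a functional assay on LNCaP cells (Homo sapiens) for antiproliferative activity, read by propidium iodide staining, with a stated time of 96 h (a lower number here means a stronger inhibitor, a higher number a weaker inhibitor), where compound 1 gives 100000 nM. Compound 2 `CC(O)(COc1ccc(C#N)cc1C(F)(F)F)C(=O)Nc1ccc(S(F)(F)(F)(F)F)cc1` carries trifluoromethyl in place of hydrogen on an aromatic carbon, and in this assay compound 2 gives 100000 nM, so that no change at the digits printed from compound 1 to compound 2 (within the scatter). Compound 3 `CC(O)(COc1ccc(C#N)cc1)C(=O)Nc1cccc(S(F)(F)(F)(F)F)c1` is built on a different core, and the difference between the two cores is not broken down here. In this assay compound 3 gives 30000 nM, the lowest of the three numbers and beyond the scatter from both compound 1 and compound 2. Compound 4 `CC(O)(COc1ccc(C#N)cc1C(F)(F)F)C(=O)Nc1cccc(S(F)(F)(F)(F)F)c1` has not been measured; it differs from compound 3 by trifluoromethyl in place of hydrogen on an aromatic carbon, the same change as that from compound 1 to compound 2. Because no change at the digits printed from compound 1 to compound 2 (within the scatter), a step of no change at the digits printed from compound 3 to compound 4 (within the scatter) is expected. Compound 4 is therefore estimated at 30000 nM, with an expected range from 10000 nM to 100000 nM.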

Compound 4, half-maximal inhibitory concentration: 16400 nM
Estimate against measurement, compound 4: 1.8-fold (0.26 log units) above; the measured number falls inside the stated range.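

In this assay, trifluoromethyl in place of hydrogen on an aromatic carbon gives a 1.8-fold lower number from compound 3 to compound 4 (0.26 log units; within the scatter). Set beside the earlier step, the change reads the same on both cores, with no difference that can be told apart from ordinary repeat-to-repeat variation: the same change on two cores in this assay, no change at the digits printed (within the scatter) from compound 1 to compound 2 and a 1.8-fold lower number (0.26 log units; within the scatter) from compound 3 to compound 4, 1.8-fold (0.26 log units) apart, within the scatter of two such steps. This shows that, on these two cores, adding the group leaves the number within the scatter, but it does not show that the group would behave the same way on any other core.

The compounds shown leave open whether a different group at this place, such as an amine or a carboxylic acid, would move the number beyond the scatter. They also leave open what this same change would do on a third core.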